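A few compounds are considered here, and "the series" means these few. Any claim that something is new, unique, unknown or untested is made for them only; others in the source may bear on it.

Compound 1 `COc1ccc(/C=C/C2CC=CC(=O)O2)cc1OC` gives 16.8 uM in a functional assay on OVCAR-3 cells (Homo sapiens) for inhibition, read by sulforhodamine B assay, with a stated time of 48 h; a lower number here means a stronger inhibitor of growth, a higher number a weaker inhibitor of growth. Compound 2 `COc1cc(/C=C/C2CC=CC(=O)O2)cc(OC)c1OC` gives 44.9 uM in this assay, and the step of a 2.7-fold higher number from compound 1 to compound 2 (0.43 log units; beyond the scatter) goes with the change (methoxy in place of hydrogen on an aromatic carbon). Compound 3 `COc1ccc(/C=C/C2CC=CC(=O)N2)cc1` gives 787 uM in this assay, the highest of the three numbers; the difference between its core and the core of compound 1 is not broken down here. Compound 4 `COc1ccc(/C=C/C2CC=CC(=O)N2)cc1OC` carries the change (methoxy in place of hydrogen on an aromatic carbon), the same kind of change as that from compound 1 to compound 2, though in compound 2 the place is also meta to a methoxy group, which is not so in compound 4. Resting on the modest step of a 2.7-fold higher number from compound 1 to compound 2 (0.43 log units; beyond the scatter), the expected step is a 1.3-fold higher number from compound 3 to compound 4 (0.10 log units; within the scatter). Compound 4 is therefore expected to give 1000 uM in this assay, estimated to lie between 300 uM and 3000 uM.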

Compound 4, concentration for growth inhibition (reported as GI): > 964 uM
Compound 4 gave a limit, no number (the forecaster's own chance of this, stated with the estimate: 30%); the middle value is on the limit's open side.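

In this assay compound 4 gave a limit of the assay, > 964 uM, and not a number. The new step, an at least 1.2-fold higher number from compound 3 to compound 4 (0.08 log units; that floor lies within the scatter), is thus only a floor, and setting it beside the same methoxy change on the core of compound 1 shows little: the same change on two cores in this assay, a 2.7-fold higher number (0.43 log units; beyond the scatter) from compound 1 to compound 2 and an at least 1.2-fold higher number (0.08 log units; that floor lies within the scatter) from compound 3 to compound 4; the limit leaves it open whether they differ. The result shows neither that the change carries from one core to the other with the same size nor that it does not, and a single pair on each core would support no general rule.

The compounds shown leave open how the core of compound 3 responds to other groups on the aromatic ring, such as a hydroxyl or an amine. They also leave open what a fluorine in place of the added methoxy would do on either core.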